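Swapping Thiophen-2-yl for Phenyl on a Weak Core

A few compounds are considered here, and "the series" means these few. Any claim that something is new, unique, unknown or untested is made for them only; others in the source may bear on it.

Four compounds share a core that carries a 1-methyl-1H-pyrrol-2-yl group and a cyano group, with a further aromatic group varied. Compound 1 `COc1ccc(-c2cc(-c3cccn3C)c(C#N)c(=O)[nH]2)cc1OC` and compound 2 `COc1ccc(-c2cc(-c3cccn3C)c(C#N)c(N)n2)cc1OC` carry the same aryl group and differ elsewhere in the core. In a functional assay on HCT-116 cells (Homo sapiens) for inhibition, read by sulforhodamine B assay, with a stated time of 48 h (on this read-out higher numbers stand for weaker inhibition of growth and lower numbers for stronger inhibition of growth), compound 1 gives 91200 nM. In this assay compound 2 gives 89100 nM. These two values lie within the scatter of each other, so neither can be called the stronger.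

Compound 3 `Cn1cccc1-c1cc(-c2cccs2)[nH]c(=O)c1C#N` carries a thiophen-2-yl group in place of that aryl group. For compound 3, this assay reports only a limit of the assay, > 100000 nM. Compound 3 therefore sits at the limit of > 100000 nM in this assay, at which 1 of the 3 values shown sits, and its true value is not known as a number.

Compound 4 `Cn1cccc1-c1cc(-c2ccccc2)[nH]c(=O)c1C#N` differs from compound 3 in one place: phenyl in place of thiophen-2-yl on an aromatic carbon. Going by the values given here, no step between measured compounds shows how much such a change moves the read-out. All three measured compounds show weak growth inhibition, and the step that the limit leaves unreadable from compound 3 to compound 4 is expected to stay within the scatter, with a fair chance that only a limit is again reported. Compound 4 is therefore expected to give 120000 nM in this assay, with a range from 50000 nM to 300000 nM.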

Compound 4, concentration for 50% growth inhibition: > 100000 nM
Compound 4: a limit, no number; the forecaster's own chance of this, stated with the estimate: 55%; the middle value does not contradict the limit.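

In this assay compound 4 gives > 100000 nM, which is a limit and not a number. Compound 3 also stands at a limit, so the step from compound 3 to compound 4 cannot be read. The two compounds share one limit: the limit of > 100000 nM in this assay, at which 2 of the 4 values shown sit. The compounds shown leave open whether phenyl and thiophen-2-yl differ at all in their effect on growth inhibition.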